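Adding a Nitrile to a Weak Receptor Binder

This account rests on a few compounds, and the source may have more. Where it says the series, first, only, none or still open, it means among the compounds named here.

Compound 1 `CC(=O)/C(=N\Nc1ccccc1)Nc1cccc(Cl)c1` was measured in an assay on isolated protein for binding affinity to corticotropin-releasing factor receptor 1 (Homo sapiens) (a higher number here means a weaker inhibitor, a lower number a stronger inhibitor), and gave 2720 nM; 2720 nM (2 entries). Compound 2 `CC(=O)/C(=N\Nc1ccccc1)N(C)c1cccc(Cl)c1` returns only > 10000 nM in this assay, a limit rather than a number. Compound 3 `CC(=O)/C(=N\Nc1ccccc1)Oc1cccc(Cl)c1` likewise returns only the limit > 10000 nM. Compound 2 therefore stands at the limit of > 10000 nM in this assay, at which 2 of the 3 values shown sit, so no single number places it against the others. Compound 4 `CC(=O)/C(=N\Nc1ccccc1C#N)N(C)c1cccc(Cl)c1` differs from compound 2 by cyano in place of hydrogen on an aromatic carbon. Among the compounds with values here, no measured pair shows such a change, so its size and direction in this assay are open, and with compound 2 at a limit even a step beyond the scatter could remain unseen. Compound 4 is expected to give about 12000 nM, between 3000 nM and 40000 nM. The step that the limit leaves unreadable from compound 2 to compound 4 is estimated to be small.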

Compound 4, inhibition constant: > 10000 nM
Compound 4: no number, only a limit; the forecaster's own chance of this, stated with the estimate: 60%; the middle value does not contradict the limit.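

Compound 2 and compound 4 both stand at a limit, so no step between them can be read: the limit of > 10000 nM in this assay, at which 3 of the 4 values shown sit.

The compounds shown leave open whether cyano in place of hydrogen on an aromatic carbon changes the value at all, and in which direction.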